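The source may hold more compounds than are shown below. What is called first, only, known or untested is meant among the compounds shown, and "the series" means these compounds.

Working notes on the series. Compound 1 `CCc1cc(C(C)=O)c(O)cc1OCCCCC(C)(C)C#N`, compound 2 `CCc1cc(C(C)=O)c(O)cc1OCCCCCCC(C)(C)C#N` and compound 3 `CCc1cc(C(C)=O)c(O)cc1OCCCCCC[S+](C)[O-]` share one core and differ only in the chain on the aromatic oxygen. In an assay on isolated protein for inhibition of leukotriene B4 receptor 1 (Homo sapiens), tested at 10 uM (on this read-out lower numbers stand for less inhibition and higher numbers for more inhibition at the one concentration tested (going by the name of the read-out)), compound 1 gives 79%, compound 2 gives 65% and compound 3 gives 92%. Compound 3 stands highest of the three; the step of a number 13 percentage points higher from compound 1 to compound 3 (beyond the scatter) and the step of a number 27 percentage points higher from compound 2 to compound 3 (beyond the scatter) both go beyond the scatter, and the step of a number 14 percentage points lower from compound 1 to compound 2 (beyond the scatter) shows that the two nitrile-bearing chains are themselves told apart.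

Compound 4 `CCc1cc(C(C)=O)c(O)cc1OCCCCCCC(=O)O` is not yet measured. Relative to compound 3 the change is a group of 3 heavy atoms (1 carbon, 2 oxygen; no ring) in place of a group of 3 heavy atoms (1 carbon, 1 oxygen, 1 sulfur; no ring), on a saturated chain carbon, six bonds along the chain from an oxygen on an aromatic ring. Within the data shown here, no measured step involves a carboxy group, so the nearest guide is the step of a number 27 percentage points higher from compound 2 to compound 3 (beyond the scatter), which shows that the group six bonds along the chain can move this read-out by a modest amount. A modest decrease from compound 3 is therefore expected, with the step of a number 14 percentage points lower from compound 3 to compound 4 (beyond the scatter) estimated. Compound 4 is expected to give 78% in this assay, within the range 55% to 95%.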

Compound 4, a percentage reported as inhibition, at one concentration (the size of the read-out at that concentration, not a potency): 87%
Compound 4: the middle estimate sits 9 percentage points below what was measured; the measured number falls inside the stated range.
By their numbers in this assay, from the lowest: compound 2; then compounds 1, 4 and 3 (each within the scatter of the next, the first and the last beyond it).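

In this assay a carboxy group on a saturated chain carbon, six bonds along the chain from an oxygen on an aromatic ring, cannot be told apart from the sulfur-bearing group it replaces, as a number 5 percentage points lower from compound 3 to compound 4 (within the scatter) shows. The end of the chain still matters at this place, since a number 22 percentage points higher from compound 2 to compound 4 (beyond the scatter) puts carboxy clear of 1-cyano-1-methylethyl, whereas 2-carboxyethyl in place of 1-cyano-1-methylethyl four bonds along the chain gives a number 8 percentage points higher from compound 1 to compound 4 (within the scatter) and no separation. Nothing at hand bears on why these readings fall as they do.

From the compounds shown here alone, whether an amine or a primary amide at the same place would read like carboxy remains open. So does whether a longer chain ending in a carboxylic acid would keep this level in this assay.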